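A Bromine Added to a Benzyl Group at the Assay Limit

The source may hold more compounds than are shown below. What is called first, only, known or untested is meant among the compounds shown, and "the series" means these compounds.

Compound 1, `OC1CN(Cc2cccc(Br)c2)CCC1N1CCN(c2ccccc2)CC1`: 66 nM
Compound 2, `OC1CCNCC1N1CCN(c2ccccc2)CC1`: > 100 nM
Compound 3, `OC1CCN(Cc2ccccc2)CC1N1CCN(c2ccccc2)CC1`: > 100 nM

Of the compounds shown here, three on a shared core have been tested in an assay on PC-12 cells for displacement of a labelled ligand from vesicular acetylcholine transporter (Homo sapiens); a higher number here means a weaker inhibitor, a lower number a stronger inhibitor. In this assay compound 1, `OC1CN(Cc2cccc(Br)c2)CCC1N1CCN(c2ccccc2)CC1`, gives 66 nM. Compound 2, `OC1CCNCC1N1CCN(c2ccccc2)CC1`, gives only a limit of the assay, > 100 nM. Compound 3, `OC1CCN(Cc2ccccc2)CC1N1CCN(c2ccccc2)CC1`, likewise gives only a limit, > 100 nM. Going by the values given here, the single measured step, a step that the two limits leave unreadable from compound 2 to compound 3, has no readable size because of the limit of > 100 nM in this assay, at which 2 of the 3 values shown sit. Compound 3 thus stands at the limit of this assay, with one of the two other values sitting at the same limit and only compound 1 giving a number.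

Compound 4, `OC1CCN(Cc2cccc(Br)c2)CC1N1CCN(c2ccccc2)CC1`, differs from compound 3 by bromo in place of hydrogen on an aromatic carbon. Among the compounds with values here, compound 1 also carries a 3-bromobenzyl group, but no single step joins it to compound 4, and the only measured step gives no usable size. The change from compound 3 to compound 4 therefore has no measured precedent among these compounds, and neither its direction nor its size in this assay can be read from them. Compound 4 is estimated at 150 nM, within 40 nM to 600 nM. This estimate for compound 4 means an expected step that the limit leaves unreadable from compound 3 to compound 4.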

Compound 4, half-maximal inhibitory concentration: 46 nM
For compound 4 the middle estimate is 3.3-fold (0.51 log units) above the measured one, and the stated range covers the measured number.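

In this assay, going by these compounds alone, bromo in place of hydrogen on an aromatic carbon, meta to a large group, gives an at least 2.1-fold lower number from compound 3 to compound 4 (0.33 log units; beyond the scatter) and so provides the first readable step on the shared core, one that lies beyond the scatter. Setting 3-bromobenzyl in place of hydrogen on the amine nitrogen in the ring gives an at least 2.1-fold lower number from compound 2 to compound 4 (0.33 log units; beyond the scatter) and is also readable, whereas plain benzyl at that nitrogen leaves the step from compound 2 to compound 3 unreadable. Both new steps give only a smallest size, and their full size cannot be read because compound 2 and compound 3 each stand at a limit of the assay: the limit of > 100 nM in this assay, at which 2 of the 4 values shown sit.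

The compounds shown leave open whether chloro or methoxy on the same aromatic carbon would give a step like that of bromo. They also leave open how the core of compound 1 would read with plain benzyl, so the bromo step cannot yet be compared on that core.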